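This account rests on a few compounds, and the source may have more. Where it says the series, first, only, none or still open, it means among the compounds named here.

Compound 2 `CCOc1ccc(Br)cc1C(C)NC(=O)N(C)S(=O)(=O)c1ccc(C)cc1` and compound 4 `CCOc1ccc(Br)cc1C(C)NC(=O)N(C)S(=O)(=O)c1ccc(Cl)cc1` share a core; how that core differs from the core of compound 3 `Cc1ccc(S(=O)(=O)NC(=O)NC(C)c2ccccc2OCc2ccccc2)cc1` is not broken down here, and compound 1 `CC(NC(=O)NS(=O)(=O)c1ccc(Cl)cc1)c1ccccc1OCc1ccccc1` carries the core of compound 3. In a functional assay on thoracic aorta (Rattus norvegicus, strain Wistar), with a stated time of 15 min (a lower number here means that less compound is needed, a higher number that more compound is needed for the effect), compound 2 gives 28600 nM, while compound 1 gives 157000 nM. Compound 3 reaches only a limit of this assay, > 200000 nM. Of the three values shown, this one sits at the limit of > 200000 nM in this assay, at which 1 of the 3 values shown sits. Compound 2 thus holds the lowest of the two numbers, with compound 1 at a gap beyond the usual scatter.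

The change that joins the two pairs is the same in each: chloro in place of methyl on an aromatic carbon between compound 3 and compound 1, and chloro in place of methyl on an aromatic carbon between compound 2 and compound 4, at a place described in the same words in both cases. Measured once, it produced an at least 1.2-fold lower number from compound 3 to compound 1 (0.10 log units; that floor lies within the scatter), a step that starts from a limit and so gives no more than a floor. No second measured pair is shown, and no cause for that step is given here.

On this basis compound 4 is expected to show a 1.3-fold lower number from compound 2 to compound 4 (0.11 log units; within the scatter). Going by the values given here, that expectation rests on the one measured step, an at least 1.2-fold lower number from compound 3 to compound 1 (0.10 log units; that floor lies within the scatter), and on the value of compound 2, 28600 nM. Compound 4 is therefore estimated at 22000 nM, within a range from 8000 nM to 60000 nM in this assay.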

Compound 4, half-maximal effective concentration: 55700 nM
Compound 4: the middle estimate sits 2.5-fold (0.40 log units) below what was measured; the measured number falls inside the stated range.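

On the shared core of compound 2 and compound 4, the change from 4-methylphenyl to 4-chlorophenyl gives a 1.9-fold higher number from compound 2 to compound 4 (0.29 log units; within the scatter) in this assay, a step that stays inside the usual scatter of repeated measurements. Set beside the earlier step, this result establishes neither that the change carries over from one core to the other with the same size nor that its size differs between them: the same change on two cores in this assay, an at least 1.2-fold lower number (0.10 log units; that floor lies within the scatter) from compound 3 to compound 1 and a 1.9-fold higher number (0.29 log units; within the scatter) from compound 2 to compound 4; the limit leaves it open whether they differ Compound 3 is recorded only at a limit of the assay, > 200000 nM, so the size of the change on the core of compound 3 remains unknown, and the series shows only that neither step is read as beyond the scatter.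

What the compounds shown leave open is how other groups at the same place on the aromatic ring would read on either core, for instance a methoxy group, a nitrile, an amine or a carboxylic acid in place of the chloro. Also open is which part of the difference between the two cores goes with the values seen, as no pair shown separates the cores in a single place.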